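Acetoxy in Place of Propanoyl on the Shared Core

The source may report more compounds than this note shows. Statements on the series, on what has been measured and on what is new or still open speak of the compounds shown alone.

Three compounds have been measured in a functional assay (trachea) with Rattus norvegicus as the target; on this read-out lower numbers stand for lower potency and higher numbers for higher potency (the scale is a negative logarithm):
compound 1 `CCC(=O)c1ccc2c(c1)C(n1ccccc1=O)=CC(C)(C)O2` gives 5.85
compound 2 `CC1(C)C=C(n2ccccc2=O)c2cc(C(=O)c3cccs3)ccc2O1` gives 5.84
compound 3 `CC1(C)C=C(n2ccccc2=O)c2cc(C=O)ccc2O1` gives 6.14

Compound 1 stands second highest of the three, yet both neighbours lie within the usual scatter: a number 0.01 log units lower from compound 1 to compound 2 (within the scatter) and a number 0.29 log units higher from compound 1 to compound 3 (within the scatter), as does a number 0.30 log units higher from compound 2 to compound 3 (within the scatter). Compound 4 `CC(=O)Oc1ccc2c(c1)C(n1ccccc1=O)=CC(C)(C)O2` differs from compound 1 in one place: acetoxy in place of propanoyl on an aromatic carbon. The measured steps all alter the group attached to the carbonyl carbon of compound 1 rather than exchanging the whole group, so none bears directly on this change. They do show that varying what sits at this position left this assay unmoved beyond the scatter. No step beyond the scatter is therefore expected here either. Compound 4 is expected to give 5.9, between 5.3 and 6.5, an estimated step of a number 0.05 log units higher from compound 1 to compound 4 (within the scatter).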

Compound 4, logarithm of the reciprocal of the active concentration, log(1/C): 4.97
Compound 4: the middle estimate sits 0.93 log units above what was measured; the measured number lies below the stated range.
By their numbers in this assay, from the lowest: compound 4; then compounds 2, 1 and 3 (each within the scatter of the next).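

Changes to the group on the carbonyl carbon had stayed within the scatter, but in this assay swapping the whole group for acetoxy gives a drop beyond it (a number 0.88 log units lower from compound 1 to compound 4 (beyond the scatter)). Going by these compounds alone, the drop appears against the other two compounds as well (a number 0.87 log units lower from compound 2 to compound 4 (beyond the scatter)) and (a number 1.17 log units lower from compound 3 to compound 4 (beyond the scatter)), so this position on the aromatic carbon is less tolerant than the earlier steps suggested. No available measurement explains the drop. Going by these compounds, whether an amine or a carboxylic acid on this aromatic carbon would keep the higher numbers or lose them remains open.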